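This account rests on a few compounds, and the source may have more. Where it says the series, first, only, none or still open, it means among the compounds named here.

Compound 1 `O=C1C(=O)N(CCCCCn2cc(COc3cc(=O)oc4ccccc34)nn2)c2ccc(Cl)cc21` gives 48% in a functional assay on COLO 205 cells (Homo sapiens) for inhibition, read by sulforhodamine B assay, with a stated time of 48 h, tested at 50 uM; a higher number here means more inhibition of growth at the concentration tested, a lower number less inhibition of growth.
Compound 2 `O=C1C(=O)N(CCCCCn2cc(COc3cc(=O)oc4ccccc34)nn2)c2ccc([N+](=O)[O-])cc21` gives 23%.
Compound 3 `O=C1C(=O)N(CCCn2cc(COc3cc(=O)oc4ccccc34)nn2)c2ccc(Cl)cc21` gives 67%.

Compound 1 and compound 2 differ in one place: nitro in place of chloro on an aromatic carbon. This change made a step of a number 25 percentage points lower from compound 1 to compound 2 (beyond the scatter). Compound 3 carries a different core; the difference between the two cores is not broken down here, but compound 3 stands highest of the three, with both other values lying beyond the usual scatter below it.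

Compound 4 `O=C1C(=O)N(CCCn2cc(COc3cc(=O)oc4ccccc34)nn2)c2ccc([N+](=O)[O-])cc21` has not yet been measured. It differs from compound 3 by nitro in place of chloro on an aromatic carbon, the same change, at the same place, as that from compound 1 to compound 2. Resting on the measured step of a number 25 percentage points lower from compound 1 to compound 2 (beyond the scatter), a step of similar size is expected, namely a number 25 percentage points lower from compound 3 to compound 4 (beyond the scatter). Compound 4 is thus estimated at 42%, with a likely range from 25% to 58%.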

Compound 4, percent growth inhibition at one concentration: 52%
The estimate for compound 4 lay 10 percentage points below the measured number; measured number inside the range.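

Replacing chloro with nitro in this assay gives a number 15 percentage points lower from compound 3 to compound 4 (beyond the scatter). Set beside the earlier step, the two agree: the same change on two cores in this assay, a number 25 percentage points lower (beyond the scatter) from compound 1 to compound 2 and a number 15 percentage points lower (beyond the scatter) from compound 3 to compound 4, 10 percentage points apart, within the scatter of two such steps. The change therefore carried over from the core of compound 1 to the core of compound 3 with the same direction and a similar size, but two pairs tested at one concentration do not show that it would hold on any other core, nor do they explain why nitro gives the lower number.

The compounds shown leave open what an amine or a carboxylic acid would do at this place on the aromatic ring. They also leave open whether the step would persist with a longer chain.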